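Para-substituent on the pendant phenyl: halogen, methyl, then hydrogen

The compounds below may be only part of what the source reports. "The series", "measured", "known", "first", "only" and "open" are said of these compounds alone.

Three members of the series share one core and differ only in the group on the pendant phenyl. Compound 1 `COc1cc(/C=C/C(=O)OCCSc2nc(-c3ccc(S(C)(=O)=O)cc3)n(-c3ccc(Br)cc3)n2)ccc1OC(C)=O` carries bromo and gives 940 nM in an assay on cells (strain Sprague-Dawley) for inhibition of Polyunsaturated fatty acid 5-lipoxygenase (Rattus norvegicus), with a stated time of 30 min; on this read-out lower numbers stand for stronger inhibition and higher numbers for weaker inhibition. Compound 2 `COc1cc(/C=C/C(=O)OCCSc2nc(-c3ccc(S(C)(=O)=O)cc3)n(-c3ccc(F)cc3)n2)ccc1OC(C)=O` carries fluoro and gives 920 nM in this assay. Compound 3 `COc1cc(/C=C/C(=O)OCCSc2nc(-c3ccc(S(C)(=O)=O)cc3)n(-c3ccc(C)cc3)n2)ccc1OC(C)=O` carries methyl and gives 980 nM in this assay. Compound 3 holds the highest of the three numbers, but only by the narrowest of margins, and the series as a whole is flat: a 1.0-fold lower number from compound 1 to compound 2 (0.01 log units; within the scatter), a 1.0-fold higher number from compound 1 to compound 3 (0.02 log units; within the scatter), a 1.1-fold higher number from compound 2 to compound 3 (0.03 log units; within the scatter). None of these three steps leaves the scatter, so the group at this position has so far made no detectable difference.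

Compound 4 `COc1cc(/C=C/C(=O)OCCSc2nc(-c3ccc(S(C)(=O)=O)cc3)n(-c3ccccc3)n2)ccc1OC(C)=O` is the next member. The change from compound 3: hydrogen in place of methyl on an aromatic carbon, at the place described as on an aromatic carbon of a six-membered aromatic ring of carbon only, para to a large group. All three measured steps bear on it, since each exchanges one group at the same position, and each stayed within the scatter. Compound 4 is therefore expected to sit where the others do, with a 1.0-fold lower number from compound 3 to compound 4 (0.01 log units; within the scatter) not beyond the scatter in either direction. The estimate for compound 4 in this assay is 950 nM, with a range of 500 nM to 1800 nM.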

Compound 4, half-maximal inhibitory concentration: 960 nM
Estimate against measurement, compound 4: 1.0-fold (0.00 log units) below, and the stated range covers the measured number.
By their numbers in this assay, from the lowest: compounds 2, 1, 4 and 3 (each within the scatter of the next).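

Compound 4 supplies the reference the halogen and methyl members lacked: a plain phenyl, with hydrogen on the aromatic carbon para to a large group. In this assay, a 1.0-fold lower number from compound 3 to compound 4 (0.01 log units; within the scatter) and a 1.0-fold higher number from compound 2 to compound 4 (0.02 log units; within the scatter) and also a 1.0-fold higher number from compound 1 to compound 4 (0.01 log units; within the scatter) all stay within the scatter, so bromo, fluoro and methyl are each indistinguishable from hydrogen here, and none of the three is needed for the read-out to hold at this level. Nothing available bears on why this place tolerates these exchanges so evenly.

As far as these compounds go, the four compounds span only hydrogen, two halogens and methyl, so it remains open whether the flat picture survives a group of another kind, such as an amine, a carboxylic acid, a methoxy group or a longer chain such as n-butyl. Also open, from the compounds shown here alone, is whether the same exchanges stay as flat when the rest of the shared core is changed, for instance with the methylsulfonyl group replaced by a sulfonamide, since all four compounds carry that part unchanged.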